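Chloro for Bromo on a Fused Aromatic Ring

This account rests on a few compounds, and the source may have more. Where it says the series, first, only, none or still open, it means among the compounds named here.

Compound 1 `CN(C)c1ccc(C2CC(c3ccccc3)=NN2C2=NC(=O)/C(=C3\C(=O)Nc4ccc(Br)cc43)S2)cc1` and compound 2 `CN(C)c1ccc(C2CC(c3ccccc3)=NN2C2=NC(=O)/C(=C3\C(=O)Nc4ccc(Cl)cc43)S2)cc1` share one core and differ only at the halogen. In a functional assay on cells (Cancer cell lines, Homo sapiens) for cytotoxicity, read by sulforhodamine B assay, with a stated time of 48 h (on this read-out lower numbers stand for stronger inhibition of growth and higher numbers for weaker inhibition of growth), compound 1 gives 510 nM, and compound 2 gives 530 nM. The step of a 1.0-fold higher number from compound 1 to compound 2 (0.02 log units; within the scatter) comes from the change (chloro in place of bromo on an aromatic carbon).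

Compound 3 `COc1ccc(-c2cc(-c3ccc(Cl)cc3)n(C3C(=O)Nc4ccc(Br)cc43)n2)cc1` is built on a different core; the difference between the two cores is not broken down here. In this assay compound 3 gives 24600 nM, the highest number of the three measured compounds, beyond the scatter from both compound 1 and compound 2.

Compound 4 `COc1ccc(-c2cc(-c3ccc(Cl)cc3)n(C3C(=O)Nc4ccc(Cl)cc43)n2)cc1` is the chloro counterpart of compound 3, made by the same change, (chloro in place of bromo on an aromatic carbon), at the same place as in the pair of compound 1 and compound 2. Because that earlier step was a 1.0-fold higher number from compound 1 to compound 2 (0.02 log units; within the scatter), the step from compound 3 to compound 4 is expected to be a 1.0-fold higher number from compound 3 to compound 4 (0.01 log units; within the scatter). On that basis compound 4 is estimated at 25000 nM in this assay, expected to fall between 12000 nM and 50000 nM.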

Compound 4, concentration for total growth inhibition: 17800 nM
Compound 4: the middle estimate sits 1.4-fold (0.15 log units) above what was measured; the measured number falls inside the stated range.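

In this assay, chloro in place of bromo on an aromatic carbon gives a 1.4-fold lower number from compound 3 to compound 4 (0.14 log units; within the scatter), so on the core of compound 3 this step stays within the scatter. Set beside the earlier step, the two cores handle the change alike: the same change on two cores in this assay, a 1.0-fold higher number (0.02 log units; within the scatter) from compound 1 to compound 2 and a 1.4-fold lower number (0.14 log units; within the scatter) from compound 3 to compound 4, 1.4-fold (0.16 log units) apart, within the scatter of two such steps

This shows that, in these two pairs, exchanging bromo for chloro carries from one core to the other as a step within the scatter. It does not show that the same would hold on any further core, and as neither step rises above the scatter, it cannot tell whether a change with a larger effect would carry across in the same way.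

The compounds shown hold only bromo or chloro at this place, so what fluoro, a nitrile or an amine would do there on either core stays open. Going by these compounds, whether the two pairs would behave alike in any other assay also stays open.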